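The source may report more compounds than this note shows. Statements on the series, on what has been measured and on what is new or still open speak of the compounds shown alone.

Measured compounds:
- compound 1 `C=CCN(C)c1nc(N)nc2c1ncn2[C@H]1C[C@H](N=[N+]=[N-])[C@@H](CO)O1`: > 100000 nM
- compound 2 `C=CCNc1ncnc2c1ncn2[C@H]1C[C@H](N=[N+]=[N-])[C@@H](CO)O1`: 51100 nM

Compound 1 carries an allyl(methyl)amino group on the shared core. In an ADME assay on PBMC cells (Homo sapiens) for cytotoxicity, with a stated time of 5 days (on this read-out higher numbers stand for weaker inhibition and lower numbers for stronger inhibition), compound 1 gives > 100000 nM, and this is a limit of the assay rather than a number (the limit of > 100000 nM in this assay, at which 1 of the 2 values shown sits). Where compound 1 stands can therefore be said only as a range, not as a point. Compound 2 is a related compound with an allylamino group in place of the allyl(methyl)amino group and without the amino group on the core; in this assay compound 2 gives 51100 nM.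

Compound 3 `CN(C)c1nc(N)nc2c1ncn2[C@H]1C[C@H](N=[N+]=[N-])[C@@H](CO)O1` is the compound still to be measured. It differs from compound 1 by hydrogen in place of vinyl on a saturated chain carbon bound to a nitrogen on an aromatic ring. For the measured compounds named here, no measured pair shows this change, so no step size can be read off. Because compound 1 sits at the limit (the limit of > 100000 nM in this assay, at which 1 of the 2 values shown sits), the step from compound 1 to compound 3 is expected to be a step that the limit leaves unreadable from compound 1 to compound 3, that is, none beyond the scatter, with a good chance that only a limit is reported again. In this assay compound 3 is estimated at 150000 nM, within a range of 60000 nM to 400000 nM.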

Compound 3, half-maximal inhibitory concentration: > 100000 nM
Compound 3 gave a limit, no number (the forecaster's own chance of this, stated with the estimate: 75%); the middle value lies beyond the limit too.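

Compound 1 and compound 3 both end at a limit of the assay rather than a number, so no step can be read between them: the limit of > 100000 nM in this assay, at which 2 of the 3 values shown sit.

The compounds shown leave open how far the change from allyl to methyl shifts the value in this assay.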